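The source may report more compounds than this note shows. Statements on the series, on what has been measured and on what is new or still open speak of the compounds shown alone.

Working notes on a series sharing one core, read in an ADME assay on microsomes from liver (Mus musculus) for metabolic stability, with a stated time of 10 min; on this read-out lower numbers stand for a less stable compound and higher numbers for a more stable compound. Compound 1 `CO[C@]1(C(=O)N2CC[C@](c3ccc(C(F)(C(F)(F)F)C(F)(F)F)cc3)(S(=O)(=O)c3ccc(F)cc3)C2)CC[C@H](C(=O)O)CC1` gives 95%, compound 3 `O=C(O)C12CCC(C(=O)N3CC[C@](c4ccc(C(F)(C(F)(F)F)C(F)(F)F)cc4)(S(=O)(=O)c4ccc(F)cc4)C3)(CC1)CC2` gives 73%, and compound 2 `O=C(O)[C@H]1CC[C@](F)(C(=O)N2CC[C@](c3ccc(C(F)(C(F)(F)F)C(F)(F)F)cc3)(S(=O)(=O)c3ccc(F)cc3)C2)CC1` has the entry "not determined" (no result reported). Among the measured compounds shown here, compound 3 is therefore the lower of the only two compounds with a number, and compound 2 offers no comparison.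

Next is compound 4 `NC(=O)[C@H]1CC[C@H](C(=O)N2CC[C@](c3ccc(C(F)(C(F)(F)F)C(F)(F)F)cc3)(S(=O)(=O)c3ccc(F)cc3)C2)CC1`, where the change sits on a carbonyl carbon whose other neighbours are: amide-type nitrogen in a ring. The change is a group of 9 heavy atoms (7 carbon, 1 nitrogen, 1 oxygen; one six-membered non-aromatic ring of carbon only) in place of a group of 11 heavy atoms (9 carbon, 2 oxygen; 2 six-membered non-aromatic rings of carbon only), on a carbonyl carbon. The entering 4-carbamoylcyclohexyl has one six-membered non-aromatic ring of carbon only, as does the corresponding group in compound 1, while the leaving group has 2 such rings.

For the measured compounds named here, one measured step bears on this: a number 22 percentage points lower from compound 1 to compound 3 (beyond the scatter). It runs from a group with one such ring to a group with 2, the reverse of the present change in ring count. Going by the values given here, the group in compound 1 still differs from 4-carbamoylcyclohexyl, and no measured compound carries the latter, so only part of that step is expected to be recovered. The expected move, towards higher numbers, is a number 11 percentage points higher from compound 3 to compound 4 (beyond the scatter). The estimated value for compound 4 is 84%, with an expected range of 62% to 98%.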

Compound 4, percent of the compound remaining: 100%
The estimate for compound 4 lay 16 percentage points below the measured number, and the stated range ends below it.
By their numbers in this assay, from the lowest: compound 3; then compounds 1 and 4 (each within the scatter of the next).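

In this assay, on the carbonyl carbon bonded to the ring amide nitrogen, placing 4-carbamoylcyclohexyl in place of the group with 2 six-membered non-aromatic rings of carbon only gives a number 27 percentage points higher from compound 3 to compound 4 (beyond the scatter), so both groups with a number and one such ring, in compound 1 and compound 4, now stand clear of compound 3 on the stable side, with no numbered compound against this among the three. Exchanging 4-carboxy-1-methoxycyclohexyl for 4-carbamoylcyclohexyl gives a number 5 percentage points higher from compound 1 to compound 4 (within the scatter), which shows that this place carries a carbamoyl group without the carboxylic acid and the methoxy group, and without a step beyond the scatter on this read-out. No measurement at hand explains these differences.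

The step to compound 4 changes the ring count and replaces the carboxylic acid with a carbamoyl group together, so the share of each remains unresolved. A plain 4-carboxycyclohexyl group, or the two-ring group of compound 3 with a carbamoyl group in place of its carboxylic acid, would separate them.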